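From Compound 3 to Compound 4: One Added Chloro

A few compounds are considered here, and "the series" means these few. Any claim that something is new, unique, unknown or untested is made for them only; others in the source may bear on it.

compound 1, `CCCC(C)C(=O)Nc1c(C(O)(C(F)(F)F)C(F)(F)F)ccc2ccccc12`: in an assay on LtK cells with ATP-sensitive inward rectifier potassium channel 11 (Homo sapiens) as the target (on this read-out lower numbers stand for an effect already at smaller amounts and higher numbers for an effect only at larger amounts of compound), compound 1 gives > 10000 nM, which is a limit of the assay.
compound 2, `O=C(Nc1ccc(Cl)cc1)Nc1c(C(O)(C(F)(F)F)C(F)(F)F)ccc2ccccc12`: in this assay compound 2 gives 276 nM.
compound 3, `O=C(Nc1c(C(O)(C(F)(F)F)C(F)(F)F)ccc2ccccc12)c1ccccc1Cl`: in this assay compound 3 gives 2040 nM.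

Among the two numbers, compound 3 stands highest, and compound 2 is nearest to it, a 7.4-fold higher number from compound 2 to compound 3 (0.87 log units; beyond the scatter). Compound 4, `O=C(Nc1c(C(O)(C(F)(F)F)C(F)(F)F)ccc2ccccc12)c1cccc(Cl)c1Cl`, differs from compound 3 by chloro in place of hydrogen on an aromatic carbon. Among the measured compounds shown here, none of the measured steps touches a chloro on that ring: an at least 4.9-fold lower number from compound 1 to compound 3 (0.69 log units; beyond the scatter) and an at least 36-fold lower number from compound 1 to compound 2 (1.55 log units; beyond the scatter) exchange the whole group on the carbonyl carbon, as does a 7.4-fold higher number from compound 2 to compound 3 (0.87 log units; beyond the scatter). For the measured compounds named here, with no step bearing directly on the change, the expected step is none beyond the scatter, a 1.1-fold lower number from compound 3 to compound 4 (0.05 log units; within the scatter). Compound 4 is therefore estimated at 1800 nM, with a range from 500 nM to 6000 nM.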

Compound 4, half-maximal effective concentration: > 10000 nM
Compound 4 was reported as a limit; the forecaster's own chance of this, stated with the estimate: 5%; at least 5.5-fold (0.74 log units) between middle value and limit.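

Adding one chloro ortho to the existing chloro group on the ring of compound 3 is enough to change the read-out in this assay, with an at least 4.9-fold higher number from compound 3 to compound 4 (0.69 log units; beyond the scatter). The 2,3-dichlorophenyl group also falls far short of the (4-chlorophenyl)amino group, with an at least 36-fold higher number from compound 2 to compound 4 (1.55 log units; beyond the scatter). Compound 4 gives a limit of the assay, as does compound 1, so the step between them cannot be read: the limit of > 10000 nM in this assay, at which 2 of the 4 values shown sit.

Going by these compounds, whether a fluoro or a methyl at this same position would give a comparable shift remains open. On these data alone, the true size of the step also stays unknown, since only its lower bound can be read.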